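The source may hold more compounds than are shown below. What is called first, only, known or untested is meant among the compounds shown, and "the series" means these compounds.

Measured so far:
Compound 1, `Cc1cc(OCc2cccc(F)c2)ccc1CN[C@@H](C)C(N)=O`: in an assay on Sf9 cells for inhibition of Amine oxidase [flavin-containing] A (Homo sapiens), with stated times of 15 min and 60 min (a lower number here means a stronger inhibitor, a higher number a weaker inhibitor), compound 1 gives > 10000 nM, which is a limit of the assay and not a number.
Compound 2, `C[C@H](NCc1ccc(OCc2cccc(F)c2)cc1F)C(N)=O`: in this assay compound 2 gives > 10000 nM, again a limit.

Where compound 2 stands is therefore set only by the limit of > 10000 nM in this assay, at which 2 of the 2 values shown sit. Within the data shown here, the single measured step, a step that the two limits leave unreadable from compound 1 to compound 2, cannot be read, since both ends sit at that limit; it gives no direction and no size.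

Compound 3, `C[C@H](NCc1ccc(OCc2cccc(F)c2)cc1C1CC1)C(N)=O`, is to be measured in this assay. Its change from compound 2 is cyclopropyl in place of fluoro on an aromatic carbon. Among the measured compounds shown here, no measured step bears readably on this change, so nothing in the data points to a gain or a loss beyond the scatter; the only guide is that both measured compounds sit at the limit.

Compound 3 is therefore expected to remain weak, with an estimated value of 20000 nM and a range from 4000 nM to 100000 nM. The step this estimate implies, a step that the limit leaves unreadable from compound 2 to compound 3, is expected to be unreadable against the limit.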

Compound 3, half-maximal inhibitory concentration: 75200 nM
Compound 3: middle estimate off by 3.8-fold (0.58 log units), on the low side, within the range that was stated.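

In this assay, the steps from compound 1 and compound 2 to compound 3 cannot be read, because each starts from a limit of the assay: the limit of > 10000 nM in this assay, at which 2 of the 3 values shown sit.

The compounds shown leave open how methyl, fluoro and cyclopropyl on this aromatic carbon rank against one another, and whether any group there gives real inhibition.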